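Cyclopropyl to tert-Butyl on the Amide Carbonyl

This account rests on a few compounds, and the source may have more. Where it says the series, first, only, none or still open, it means among the compounds named here.

Compound 1 `CC(=O)Nc1ccc(-c2cn([C@@H]3CN[C@H](C(=O)Nc4ccc(Cl)c(C(F)(F)F)c4)C3)nn2)cn1` and compound 2 `O=C(Nc1ccc(-c2cn([C@@H]3CN[C@H](C(=O)Nc4ccc(Cl)c(C(F)(F)F)c4)C3)nn2)cn1)C1CC1` share one core and differ only in the group on a carbonyl carbon. In a functional assay on K562/Adr cells (Homo sapiens) for inhibition, read by MTT assay, with a stated time of 48 h, tested at 30 uM (on this read-out lower numbers stand for less inhibition and higher numbers for more inhibition at the one concentration tested (going by the name of the read-out)), compound 1 gives 33.6%, while compound 2 gives 44.3%; the step of a number 10.7 percentage points higher from compound 1 to compound 2 (beyond the scatter) corresponds to cyclopropyl in place of methyl on a carbonyl carbon. Compound 2 therefore stands highest of the two numbers measured, with compound 1 as its nearest neighbour. Compound 3 `CC(C)(C)C(=O)Nc1ccc(-c2cn([C@@H]3CN[C@H](C(=O)Nc4ccc(Cl)c(C(F)(F)F)c4)C3)nn2)cn1` changes the same place again: tert-butyl in place of cyclopropyl on a carbonyl carbon. For the measured compounds named here, the only measured step that bears on this, a number 10.7 percentage points higher from compound 1 to compound 2 (beyond the scatter), also enlarged the group on the carbonyl carbon and was modest though beyond the scatter. Since tert-butyl enlarges that group once more, a small further rise in this assay is expected for compound 3, though it may stay within the scatter. The estimate for compound 3 is 49%, with a range from 32% to 66%, an expected step of a number 4.7 percentage points higher from compound 2 to compound 3 (within the scatter).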

Compound 3, a percentage reported as inhibition, at one concentration (the size of the read-out at that concentration, not a potency): 19.1%
Compound 3: the middle estimate sits 29.9 percentage points above what was measured, and the stated range ends above it.
By their numbers in this assay, from the lowest: compound 3; then compound 1; then compound 2.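

In this assay the group on the carbonyl carbon does not follow a simple trend with size: the step of a number 25.2 percentage points lower from compound 2 to compound 3 (beyond the scatter) more than undoes the earlier rise, and the step of a number 14.5 percentage points lower from compound 1 to compound 3 (beyond the scatter) places tert-butyl under methyl as well. Going from methyl to cyclopropyl to tert-butyl, the numbers rise and then fall, so the heavy-atom count of the group does not put these compounds in order, and this position responds strongly to swapping the three-membered ring for tert-butyl. Nothing available on these compounds accounts for the drop.

The compounds shown leave open how an isopropyl or cyclobutyl group, or an amine, would read on this carbonyl carbon. They also leave open whether this order holds at other concentrations, as each compound was read at a single one.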